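From Cyclopropyl to Pentyl on a Carbonyl Carbon

The source may hold more compounds than are shown below. What is called first, only, known or untested is meant among the compounds shown, and "the series" means these compounds.

Two measured compounds share one core and differ only in the group on a carbonyl carbon. Compound 1 `COCCOC(=O)NS(=O)(=O)c1sc(CC(C)C)cc1-c1cccc(Cn2ccnc2)c1` carries 2-methoxyethoxy there, and in an assay on HEK293 cells for displacement of a labelled ligand from Type-2 angiotensin II receptor (Homo sapiens), read by scintillation counting, with a stated time of 240 min (on this read-out higher numbers stand for weaker inhibition and lower numbers for stronger inhibition), compound 1 gives 480 nM. Compound 2 `CC(C)Cc1cc(-c2cccc(Cn3ccnc3)c2)c(S(=O)(=O)NC(=O)C2CC2)s1` carries cyclopropyl instead, and in this assay compound 2 gives 340 nM. Its only neighbour on the numbers shown is compound 1, and the step of a 1.4-fold lower number from compound 1 to compound 2 (0.15 log units; within the scatter) lies within the scatter, so the two measured compounds cannot be told apart.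

Compound 3 `CCCCCC(=O)NS(=O)(=O)c1sc(CC(C)C)cc1-c1cccc(Cn2ccnc2)c1` is the next member of the set: pentyl in place of cyclopropyl on a carbonyl carbon. Going by the values given here, the only measured step that bears on this position is a 1.4-fold lower number from compound 1 to compound 2 (0.15 log units; within the scatter), which stayed within the scatter, and no other measured compound speaks to a pentyl chain at this place. On that basis compound 3 is expected to shift by only a 1.1-fold lower number from compound 2 to compound 3 (0.03 log units; within the scatter), a step not beyond the scatter. Compound 3 is therefore estimated at 320 nM in this assay, with a range from 130 nM to 800 nM.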

Compound 3, inhibition constant: 280 nM
Compound 3: the middle estimate sits 1.1-fold (0.06 log units) above what was measured; measured number inside the range.
By their numbers in this assay, from the lowest: compounds 3, 2 and 1 (each within the scatter of the next).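

In this assay, the open pentyl chain, which has no ring, takes the place of the cyclopropyl ring with a 1.2-fold lower number from compound 2 to compound 3 (0.08 log units; within the scatter) and so adds a second group change on the carbonyl carbon that stays within the scatter. Set against the 2-methoxyethoxy group, the same chain gives a 1.7-fold lower number from compound 1 to compound 3 (0.23 log units; within the scatter) and this step too stays within the scatter, so the three groups cannot be told apart on these numbers, and the position now accepts a ring, an ether-bearing chain attached through oxygen and a plain carbon chain without a measurable difference among them. No measured evidence accompanies these results, so the data give no explanation for this sameness.

The compounds shown leave open whether any group on this carbonyl carbon would move the number beyond the scatter, for example an amine or a carboxylic acid at the end of the chain, a longer chain such as decyl, or a phenyl ring. They also leave open whether the same sameness would hold on a core changed elsewhere.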